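This account rests on a few compounds, and the source may have more. Where it says the series, first, only, none or still open, it means among the compounds named here.

Measured in a toxicity assay on cells (Macrophage, Homo sapiens) for inhibition, read by MTT assay; on this read-out lower numbers stand for stronger inhibition and higher numbers for weaker inhibition:
- compound 1 `CN(C)CCCNc1nc(-c2ccc(F)cc2)nc2ccccc12`: 63000 nM
- compound 2 `CN1CCN(CCCNc2nc(-c3ccc(F)cc3)nc3ccccc23)CC1`: 40000 nM
- compound 3 `NCCNc1nc(-c2ccc(Cl)cc2)nc2ccccc12`: 15000 nM

Of these three, compound 3 stands lowest, with 15000 nM. Compound 4 `NCCNc1nc(-c2ccc(F)cc2)nc2ccccc12` differs from it by one swap: fluoro in place of chloro on an aromatic carbon, para to a large group. Going by the values given here, no measured step makes this swap. Among the compounds with values here, the only step, a 1.6-fold lower number from compound 1 to compound 2 (0.20 log units; within the scatter), changes the amine end of the chain instead. Compound 1 and compound 2 already carry 4-fluorophenyl, but their chains differ from that of compound 3, so their higher values say nothing clear about the swap alone. The expected change is small, a 1.3-fold higher number from compound 3 to compound 4 (0.12 log units; within the scatter), with no shift beyond the scatter anticipated in this assay. For compound 4 the estimated value is 20000 nM, with an expected range of 9000 nM to 45000 nM.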

Compound 4, half-maximal inhibitory concentration: 64000 nM
Estimate against measurement, compound 4: 3.2-fold (0.51 log units) below; measured number above the stated range.
By their numbers in this assay, from the lowest: compound 3; then compounds 2, 1 and 4 (each within the scatter of the next).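

In this assay the halogen at this position makes a real difference, with a 4.3-fold higher number from compound 3 to compound 4 (0.63 log units; beyond the scatter) on going from chloro to fluoro. With 4-fluorophenyl held constant, changing the chain end makes no readable difference, as both a 1.6-fold higher number from compound 2 to compound 4 (0.20 log units; within the scatter) and a 1.0-fold higher number from compound 1 to compound 4 (0.01 log units; within the scatter) lie within the scatter, so among these compounds only the chloro compound stands apart. Nothing measured here explains the halogen difference. Going by these compounds, it remains open where a bromo group at this position would fall. On these data alone, it is also open whether chloro would give a lower number on chains ending in dimethylamino or 4-methylpiperazin-1-yl.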